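This account rests on a few compounds, and the source may have more. Where it says the series, first, only, none or still open, it means among the compounds named here.

Measured compounds in an ADME assay on Vero cells (Chlorocebus sabaeus) for cytotoxicity; on this read-out lower numbers stand for higher toxicity in this test and higher numbers for lower toxicity in this test:

- compound 1 `Fc1ccc(-c2nn3ccc(NC4CCCC4)cc3c2-c2ccnc(NC3CCCC3)n2)cc1` gives 18000 nM in this assay.
- compound 2 `Fc1ccc(-c2nn3c(NC4CCCC4)cc(NC4CCCC4)cc3c2-c2ccnc(NC3CCCC3)n2)cc1` gives a limit of the assay, > 40000 nM, in this assay.
- compound 3 `Fc1ccc(-c2nn3c(Cl)cc(NC4CCCC4)cc3c2-c2ccnc(NC3CCCC3)n2)cc1` gives a limit of the assay, > 40000 nM, in this assay.

Compound 3 therefore stands not at a number but at the upper limit of the assay, and it shares that position with compound 2, as both sit at the limit of > 40000 nM in this assay, at which 2 of the 3 values shown sit. Only compound 1 returns a real value.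

The next compound, compound 4 `CSc1cc(NC2CCCC2)cc2c(-c3ccnc(NC4CCCC4)n3)c(-c3ccc(F)cc3)nn12`, is not yet measured in this assay. It differs from compound 3 in one place: methylsulfanyl in place of chloro on an aromatic carbon.

Within the data shown here, two measured steps bear on this site. Putting chloro onto the hydrogen-bearing aromatic carbon gave an at least 2.2-fold higher number from compound 1 to compound 3 (0.34 log units; beyond the scatter), and putting cyclopentylamino there gave an at least 2.2-fold higher number from compound 1 to compound 2 (0.34 log units; beyond the scatter). Between the two limits, a step that the two limits leave unreadable from compound 2 to compound 3. Either substitution at this carbon drove the value to the limit, and the size of either change beyond that cannot be read. Methylsulfanyl in place of chloro at the same carbon is expected to leave compound 4 close to where compound 3 stands, most likely at the limit again, with no step beyond the scatter expected, a number no higher from compound 3 to compound 4 (the limit leaves the size open).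

Compound 4 is therefore estimated at 40000 nM in this assay, within 20000 nM to 80000 nM.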

Compound 4, half-maximal cytotoxic concentration: > 40000 nM
Compound 4 was reported as a limit; the forecaster's own chance of this, stated with the estimate: 60%; the middle value sits exactly at the limit.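

In this assay, methylsulfanyl in place of hydrogen on the aromatic carbon next to the ring nitrogen gives an at least 2.2-fold higher number from compound 1 to compound 4 (0.34 log units; beyond the scatter), which makes it the third group at this carbon, after chloro and cyclopentylamino, to give a step in this direction. Among these compounds, compound 1, with hydrogen at this carbon, is now the only compound of the four with a real value, while the three substituted compounds all sit at a limit of the assay: the limit of > 40000 nM in this assay, at which 3 of the 4 values shown sit. The steps among compound 2, compound 3 and compound 4 cannot be read, and chloro, cyclopentylamino and methylsulfanyl therefore stay unranked against one another.

Going by these compounds, how far the three substituted compounds lie from one another past the limit stays open, and with it whether these groups differ at all in this test. Also open, on these data alone, is whether a methoxy group, a carboxylic acid or a longer chain such as butylsulfanyl on this carbon would likewise reach the limit or would return a real value.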